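A few compounds are considered here, and "the series" means these few. Any claim that something is new, unique, unknown or untested is made for them only; others in the source may bear on it.

Compound 1, `N#CCNC(=O)[C@@H]1C[C@@H](S(=O)(=O)c2ccccc2Cl)C[C@H]1C(=O)N1CCOCC1`, gives 0.5 nM in an assay on isolated protein for inhibition of cathepsin S (Homo sapiens), read by fluorescence, with a stated time of 20 min; a higher number here means a weaker inhibitor, a lower number a stronger inhibitor.
Compound 2, `N#CC1(NC(=O)[C@@H]2C[C@@H](S(=O)(=O)c3ccccc3)C[C@H]2C(=O)N2CCCCC2)CC1`, gives 0.8 nM in this assay.

Both measured compounds share the same core and are strong inhibitors in this assay. Compound 2 sits close to compound 1: the gap between them lies within the usual scatter of the measurement, so the two read as equally potent and no order between them can be claimed.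

Compound 3, `N#CC1(NC(=O)[C@@H]2C[C@@H](S(=O)(=O)c3ccccc3)C[C@H]2C(=O)N2CCC2)CC1`, has not yet been measured. It differs from compound 2 in one place: azetidin-1-yl in place of piperidin-1-yl on a carbonyl carbon. The rest of the molecule, including the nitrile-bearing ring and the sulfonyl-linked phenyl, is kept.

Among the measured compounds shown here, no measured pair in this set shows what this change does, so the expectation rests only on the two numbers above and on the fact that the amide-bound ring shrinks. A modest step toward a weaker inhibitor is expected in this assay, of a size near the edge of the scatter rather than a large loss. Compound 3 is therefore estimated at 2 nM, within a range of 0.6 nM to 7 nM, which would mean an expected step of a 2.5-fold higher number from compound 2 to compound 3 (0.40 log units; beyond the scatter).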

Compound 3, half-maximal inhibitory concentration: 10 nM
Estimate against measurement, compound 3: 5.0-fold (0.70 log units) below, outside the stated range (above it).
By their numbers in this assay, from the lowest: compounds 1 and 2 (each within the scatter of the next); then compound 3.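

The group on this carbonyl carbon turns out to matter a great deal: replacing piperidin-1-yl with azetidin-1-yl gives a 13-fold higher number from compound 2 to compound 3 (1.10 log units; beyond the scatter) in this assay while the rest of the molecule stays the same. Among the compounds shown here, compounds 1 and 2 differ in more than one place, so they could not isolate any single position, and this pair is the first to show that changing this ring alone moves the number well beyond the scatter. Nothing measured here explains why the change from piperidin-1-yl to azetidin-1-yl has so large an effect.

From the compounds shown here alone, it remains open whether the number climbs steadily as the ring gets smaller or jumps only with azetidin-1-yl; pyrrolidin-1-yl would help to settle this, while dimethylamino would test whether a ring is needed on this carbonyl carbon at all. A single pair also leaves open whether the same swap would have a step of similar size with the other parts of the molecule changed, such as the chlorine-bearing phenyl of compound 1.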